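The source may report more compounds than this note shows. Statements on the series, on what has been measured and on what is new or still open speak of the compounds shown alone.

Of the compounds shown here, three have so far been tested in a functional assay on CCRF-CEM cells (Homo sapiens) for inhibition; on this read-out lower numbers stand for stronger inhibition and higher numbers for weaker inhibition. Compound 1 (`COc1cccc(/C=C2\CCCc3ccccc3C2=O)c1OC`) gives 142000 nM, compound 2 (`O=C1/C(=C/c2ccccc2F)Cc2ccccc21`) gives 47100 nM, and compound 3 (`O=C1/C(=C/c2ccccc2[N+](=O)[O-])CCc2ccccc21`) gives 7220 nM. Compound 3 has the lowest number of the three, and its gaps to compound 2 and to compound 1 both lie beyond the usual scatter, which makes it the strongest inhibitor in this small set. For the measured compounds named here, these three compounds differ from one another in more than one place, so no single-change step among them can guide the next prediction.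

Compound 4 (`O=C1/C(=C/c2ccccc2Br)CCc2ccccc21`) differs from compound 3 in one group: bromo in place of nitro on an aromatic carbon, ortho to a large group (bromo in place of nitro on an aromatic carbon). No measurement here isolates this replacement, so the expectation in this assay is a loose one. A moderate loss of inhibition, seen as a higher number, seems more likely than a gain because compound 3 holds the lowest value at 7220 nM. The expected change is a 1.9-fold higher number from compound 3 to compound 4 (0.29 log units; within the scatter). For compound 4 the estimated value is 14000 nM, with an expected range of 4000 nM to 50000 nM.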

Compound 4, half-maximal inhibitory concentration: 25400 nM
For compound 4 the middle estimate is 1.8-fold (0.26 log units) below the measured one; low and high end bracket the measured number.
By their numbers in this assay, from the lowest: compound 3; then compounds 4 and 2 (each within the scatter of the next); then compound 1.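

For the compounds shown here, compound 3 and compound 4 form the first pair in this set that differs in one place, so this assay can now be read for a single change on an aromatic carbon, ortho to a large group. Putting bromo in place of nitro gives a 3.5-fold higher number from compound 3 to compound 4 (0.55 log units; beyond the scatter) and shows that this place is not indifferent to the group it carries, with nitro the better of the two substituents compared here, though the step is only modest. The change swaps a nitro group of 3 heavy atoms and 2 hydrogen-bond acceptors for a bromo group of 1 heavy atom and no acceptors, and no measured finding here bears on why the number rises.

A single pair cannot tell which of these differences matters, nor whether an amine or a nitrile in the same place would fall nearer to compound 3 or to compound 4. It also leaves open whether bromo in place of nitro would give a similar step on cores such as those of compound 1 and compound 2, which carry other groups.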